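Swapping fluoro for chloro on compound 1

This account rests on a few compounds, and the source may have more. Where it says the series, first, only, none or still open, it means among the compounds named here.

Measured in a functional assay on EC9706 cells (Homo sapiens) for cytotoxicity, read by MTT assay, with a stated time of 72 h; on this read-out higher numbers stand for weaker inhibition and lower numbers for stronger inhibition:
compound 1 `CCNC(=O)N1CCN(C(=S)SCc2cn(Cc3ccc(F)cc3)nn2)CC1` gives 27800 nM
compound 2 `CC(C)NC(=O)N1CCN(C(=S)SCc2cn(Cc3ccc(F)cc3)nn2)CC1` gives 12200 nM
compound 3 `CCN(C)C(=O)N1CCN(C(=S)SCc2cn(Cc3ccc(F)cc3)nn2)CC1` gives 14300 nM

Compound 1 stands at the highest of the three numbers in this assay. Its nearest neighbour is compound 3, reached by a 1.9-fold lower number from compound 1 to compound 3 (0.29 log units; within the scatter), a change that stays within the scatter. Its furthest is compound 2, reached by a 2.3-fold lower number from compound 1 to compound 2 (0.36 log units; beyond the scatter), a modest step beyond the scatter. Between the other two, a 1.2-fold higher number from compound 2 to compound 3 (0.07 log units; within the scatter) is again within the scatter.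

Compound 4 `CCNC(=O)N1CCN(C(=S)SCc2cn(Cc3ccc(Cl)cc3)nn2)CC1` is the unmeasured partner of compound 1. The difference between them is chloro in place of fluoro on an aromatic carbon of the six-membered aromatic ring of carbon only, para to a large group.

None of the three measured steps touches this ring; all of them sit at the urea end of the shared core, and they ranged from within the scatter to a modest step. Among the measured compounds shown here, there is therefore no measured step that bears directly on the change from compound 1 to compound 4, and no basis for expecting a step beyond the scatter in this assay in either direction.

For compound 4 the expected value in this assay is 25000 nM, with a range from 9000 nM to 70000 nM. The expected step is a 1.1-fold lower number from compound 1 to compound 4 (0.05 log units; within the scatter), estimated to lie within the scatter.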

Compound 4, half-maximal inhibitory concentration: > 128000 nM
Compound 4 gave a limit, no number; the forecaster's own chance of this, stated with the estimate: 5%; middle value at least 5.1-fold (0.70 log units) from the limit.
By their numbers in this assay, from the lowest: compounds 2, 3 and 1 (each within the scatter of the next, the first and the last beyond it). At a limit, above all of these: compound 4.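

In this assay, among the compounds shown here, the 4-fluorobenzyl to 4-chlorobenzyl change gives an at least 4.6-fold higher number from compound 1 to compound 4 (0.66 log units; beyond the scatter), so this end of the molecule matters to the read-out, which the earlier compounds could not show because all their differences lie at the urea end. The swap exchanges one heavy atom for one heavy atom, with no change in the counted hydrogen-bond donors, hydrogen-bond acceptors or net charge, yet it weakens inhibition beyond the scatter, whereas the steps among compounds 1, 2 and 3 are modest or within the scatter. The result for compound 4 is a limit of the assay, not a number: the limit of > 128000 nM in this assay, at which 1 of the 4 values shown sits.

On these data alone, how the number responds to other groups at this place on the ring, such as bromo, methoxy or plain hydrogen, remains open, so these two halogens alone give no trend. As far as these compounds go, it is also open whether chloro has a similar effect when combined with the isopropylamino group of compound 2 or the ethyl(methyl)amino group of compound 3.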